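The source may report more compounds than this note shows. Statements on the series, on what has been measured and on what is new or still open speak of the compounds shown alone.

Measured so far:
compound 1, `COc1cc(-c2nccn3cc(-c4ccc(F)cc4)nc23)cc(OC)c1OC`, in a functional assay on HCT-116 cells (Homo sapiens) for inhibition, read by MTT assay, with a stated time of 48 h (a higher number here means a weaker inhibitor, a lower number a stronger inhibitor), gives 263 nM
compound 2, `COc1cc(-c2nccn3cc(-c4ccc5[nH]ccc5c4)nc23)cc(OC)c1OC`, in this assay gives 23 nM
compound 3, `COc1cc(-c2nccn3cc(-c4ccc(N)cc4)nc23)cc(OC)c1OC`, in this assay gives 158 nM

Compound 1 carries the highest of the three numbers. Its nearest neighbour is compound 3, with a 1.7-fold lower number from compound 1 to compound 3 (0.22 log units; within the scatter), a gap that stays within the scatter. The furthest is compound 2, with an 11-fold lower number from compound 1 to compound 2 (1.06 log units; beyond the scatter), a step that clearly stands out.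

The compound to be measured next is compound 4, `COc1cc(-c2nccn3cc(-c4ccc(C)cc4)nc23)cc(OC)c1OC`. It differs from compound 1 in one place: methyl in place of fluoro on an aromatic carbon.

For the measured compounds named here, only one measured step bears on this change. From compound 1 to compound 3 the fluoro was also swapped for another small group on the same aromatic carbon, and the result was a 1.7-fold lower number from compound 1 to compound 3 (0.22 log units; within the scatter), within the scatter. The large step from compound 1 to compound 2 concerns a quite different kind of change and offers no guide here. Accordingly no step beyond the scatter is expected in this assay for compound 4, in either direction, and the estimated shift is a 1.1-fold lower number from compound 1 to compound 4 (0.02 log units; within the scatter). Compound 4 is expected to give about 250 nM, within a range from 100 nM to 650 nM.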

Compound 4, half-maximal inhibitory concentration: 74 nM
The estimate for compound 4 lay 3.4-fold (0.53 log units) above the measured number, and the stated range ends above it.
By their numbers in this assay, from the lowest: compound 2; then compound 4; then compounds 3 and 1 (each within the scatter of the next).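

A single heavy atom changed at this spot, on the six-membered aromatic ring of carbon only, is enough to move the number: methyl in place of fluoro gives a 3.6-fold lower number from compound 1 to compound 4 (0.55 log units; beyond the scatter). Methyl also separates from amino, with a 2.1-fold lower number from compound 3 to compound 4 (0.33 log units; beyond the scatter), even though the earlier swap of fluoro for amino stayed within the scatter, so small groups here do not all behave alike. The 4-methylphenyl compound still falls short of the 1H-indol-5-yl one, with a 3.2-fold higher number from compound 2 to compound 4 (0.51 log units; beyond the scatter), and nothing measured here gives a reason for any of these differences.

The compounds shown leave open whether a longer chain such as ethyl or propyl at this position would lower the number further than methyl does. They also leave open whether chlorine or a methoxy group would sit nearer to methyl or to fluoro.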